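Chain shortening in the triazole series: butyl to propyl

This account rests on a few compounds, and the source may have more. Where it says the series, first, only, none or still open, it means among the compounds named here.

compound 1 `COc1ccc(-c2cn(CCCN3C(=O)COc4ccccc43)nn2)cc1` at 49900 nM
compound 2 `CCCCCCc1cn(CCCN2C(=O)COc3ccccc32)nn1` at 710 nM
compound 3 `CCCCc1cn(CCCN2C(=O)COc3ccccc32)nn1` at 5700 nM

All three values come from a functional assay on IMR-32 cells (Homo sapiens) for antiproliferative activity, read by sulforhodamine B assay, with a stated time of 48 h (a higher number here means a weaker inhibitor of growth, a lower number a stronger inhibitor of growth), and compound 3 stands in the middle, with compound 2 lower and compound 1 higher. Compound 4 `CCCc1cn(CCCN2C(=O)COc3ccccc32)nn1` is still unmeasured. It differs from compound 3 by butyl to propyl, hydrogen in place of methyl on a saturated chain carbon, three bonds along the chain from an aromatic carbon.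

Within the data shown here, the closest precedent is the cut from hexyl to butyl, which gave an 8.0-fold higher number from compound 2 to compound 3 (0.90 log units; beyond the scatter) in this assay and is a larger cut of the same chain. The exchanges of 4-methoxyphenyl, a 70-fold lower number from compound 1 to compound 2 (1.85 log units; beyond the scatter) and an 8.8-fold lower number from compound 1 to compound 3 (0.94 log units; beyond the scatter), replace a different kind of group and bear only loosely on this change. A smaller step in the same direction, toward a higher number, is therefore expected. The expected step is a 2.6-fold higher number from compound 3 to compound 4 (0.42 log units; beyond the scatter) as an estimate. For compound 4 the estimated value is 15000 nM (expected range 6500 nM to 40000 nM).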

Compound 4, concentration for 50% growth inhibition: 1400 nM
Compound 4: the middle estimate sits 11-fold (1.03 log units) above what was measured; the measured number lies below the stated range.
By their numbers in this assay, from the lowest: compounds 2 and 4 (each within the scatter of the next); then compound 3; then compound 1.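

In this assay the cut from butyl to propyl runs against the cut from hexyl to butyl (a 4.1-fold lower number from compound 3 to compound 4 (0.61 log units; beyond the scatter)), so the number at this position does not follow chain length in one direction, and compound 3 is the compound that goes against any such trend. Propyl and hexyl are not separated (a 2.0-fold higher number from compound 2 to compound 4 (0.29 log units; within the scatter)), while the exchange of 4-methoxyphenyl for propyl remains a large step (a 36-fold lower number from compound 1 to compound 4 (1.55 log units; beyond the scatter)), so a short alkyl chain can read as well as the longest one shown. Nothing on hand explains why the butyl compound stands apart.

Open, as far as these compounds go, is how pentyl, ethyl or a chain longer than hexyl would read here, and so whether compound 3 is an isolated departure. Also open, from the compounds shown here alone, is how a propyl chain carrying an amine or a carboxylic acid would compare.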